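Swapping hydroxy for ethylamino on a side chain

A few compounds are considered here, and "the series" means these few. Any claim that something is new, unique, unknown or untested is made for them only; others in the source may bear on it.

Measured so far in a functional assay on A549 cells (Homo sapiens) for antiproliferative activity, read by MTT assay, with a stated time of 48 h; on this read-out higher numbers stand for weaker inhibition and lower numbers for stronger inhibition:
compound 1 `COc1ccc(C(=O)c2ccc(OC)c3c2C=CC(C)(C)O3)c(NC(=O)CO)c1` gives 100 nM
compound 2 `CCNCC(=O)Nc1cc(OC)ccc1C(=O)c1ccc(OC)c2c1OC(C)(C)C=C2` gives 1050 nM

Compound 1 holds the lower of these two numbers, and the gap to compound 2 lies beyond the usual scatter. Compound 3 (`CCNCC(=O)Nc1cc(OC)ccc1C(=O)c1ccc(OC)c2c1C=CC(C)(C)O2`) has not been measured yet. It keeps the rest of compound 1 but has ethylamino in place of hydroxy on a saturated chain carbon bound to a carbonyl carbon. Among the measured compounds shown here, compound 2, which also carries ethylamino, gives 1050 nM in this assay and so sets the only guide available. A move towards weaker inhibition, beyond the scatter, is therefore expected, with an estimated 3.0-fold higher number from compound 1 to compound 3 (0.48 log units; beyond the scatter) in this measurement. For compound 3 the estimated value is 300 nM within an expected range of 60 nM to 1500 nM in this measurement.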

Compound 3, half-maximal inhibitory concentration: 2310 nM
The estimate for compound 3 lay 7.7-fold (0.89 log units) below the measured number; the measured number lies above the stated range.
By their numbers in this assay, from the lowest: compound 1; then compound 2; then compound 3.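

Ethylamino in place of hydroxy on a saturated chain carbon bound to a carbonyl carbon gives a 23-fold higher number from compound 1 to compound 3 (1.36 log units; beyond the scatter) in this assay and so isolates the cost of this one change on an otherwise unchanged core. This position is therefore sensitive to the swap, even though the counts of hydrogen-bond donors and acceptors stay the same. No measured evidence bears on why the inhibition weakens.

From the compounds shown here alone, it remains open whether the nitrogen or the ethyl carbons matter more. A plain amino group or a propyl chain at this place would help separate the two.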